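This account rests on a few compounds, and the source may have more. Where it says the series, first, only, none or still open, it means among the compounds named here.

Compound 1, with the structure `COc1ccc(-c2nc3ccccc3s2)cc1NC(=O)c1cc([N+](=O)[O-])ccc1Cl`, was tested in an ADME assay on HepG2 cells (Homo sapiens) for cytotoxicity, with a stated time of 72 h; on this read-out lower numbers stand for an effect already at smaller amounts and higher numbers for an effect only at larger amounts of compound. In this assay compound 1 gives > 25000 nM, which is a limit of the assay rather than a number. Compound 2, `COc1ccc(-c2nc3ccccc3s2)cc1NC(=O)c1cc([N+](=O)[O-])c(N2CCC(C(=O)O)CC2)cc1Cl`, likewise gives only a limit in this assay, namely > 25000 nM. The same holds for compound 3, `COC(=O)C1CCN(c2cc(Cl)c(C(=O)Nc3cc(-c4nc5ccccc5s4)ccc3OC)cc2[N+](=O)[O-])CC1`, whose result in this assay is > 25000 nM. Because all three results sit at the limit of > 25000 nM in this assay, at which 3 of the 3 values shown sit, the steps between these compounds cannot be read: a step that the two limits leave unreadable from compound 1 to compound 2, a step that the two limits leave unreadable from compound 1 to compound 3 and a step that the two limits leave unreadable from compound 2 to compound 3 all stay without a readable size. Compound 4, `O=C(Nc1cc(-c2nc3ccccc3s2)ccc1F)c1cc([N+](=O)[O-])ccc1Cl`, has not yet been measured. It differs from compound 1 by fluoro in place of methoxy on an aromatic carbon. Within the data shown here, none of the measured steps touches this part of the molecule, so no measured step bears directly on the change. Since every measured compound stays at the limit, compound 4 is expected to remain at a limit as well, and the expected step is a step that the limit leaves unreadable from compound 1 to compound 4. The estimate for compound 4 is 30000 nM, ranging from 15000 nM to 100000 nM.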

Compound 4, half-maximal effective concentration: > 25000 nM
Compound 4 was reported as a limit; the forecaster's own chance of this, stated with the estimate: 85%; the middle value lies beyond the limit too.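

Compound 4, like compound 1, gives only a limit in this assay, so no size can be read for the change from compound 1 to compound 4: the limit of > 25000 nM in this assay, at which 4 of the 4 values shown sit.

The compounds shown leave open whether fluoro in place of methoxy alters this read-out, and at what amount any of these compounds would show an effect.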